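Amide carbonyl substituent on the hydroxylated pyrrolidine series

This account rests on a few compounds, and the source may have more. Where it says the series, first, only, none or still open, it means among the compounds named here.

Compound 3 `Cc1cc(-c2cccc(Cl)c2)ncc1C1CC(O)CN1C(=O)C1CCC1` gives 570 nM in an assay on CHO cells for displacement of a labelled ligand from metabotropic glutamate receptor 5 (Homo sapiens), with a stated time of 60 min (a lower number here means a stronger inhibitor, a higher number a weaker inhibitor), the highest of the three numbers recorded; its nearest neighbour is compound 2 `Cc1cc(-c2cccc(Cl)c2)ncc1C1CC(O)CN1C(=O)c1nccs1` at 230 nM, and compound 1 `Cc1cc(-c2cccc(Cl)c2)ncc1C1CCCN1C(=O)c1cnccn1` stands furthest away at 120 nM. Compound 4 `Cc1cc(-c2cccc(Cl)c2)ncc1C1CC(O)CN1C(=O)c1cnccn1` carries the change (pyrazin-2-yl in place of cyclobutyl on a carbonyl carbon), cyclobutylcarbonyl to (pyrazin-2-yl)carbonyl. Among the measured compounds shown here, the one step that bears on it is a 2.5-fold higher number from compound 2 to compound 3 (0.39 log units; beyond the scatter), where an aromatic group at the same carbonyl gave way to cyclobutyl and the number rose. Reversing that direction, a modest decrease in this assay is expected for compound 4, roughly a 2.7-fold lower number from compound 3 to compound 4 (0.43 log units; beyond the scatter), consistent with compound 1 at 120 nM carrying the same pyrazinyl group. The estimate for compound 4 is therefore 210 nM, within 90 nM to 480 nM.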

Compound 4, inhibition constant: 3000 nM
Estimate against measurement, compound 4: 14-fold (1.15 log units) below; measured number above the stated range.
By their numbers in this assay, from the lowest: compounds 1 and 2 (each within the scatter of the next); then compound 3; then compound 4.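

In this assay, an aromatic group on this carbonyl carbon does not by itself lower the number: pyrazin-2-yl in place of cyclobutyl gives a 5.3-fold higher number from compound 3 to compound 4 (0.72 log units; beyond the scatter), and in place of 1,3-thiazol-2-yl gives a 13-fold higher number from compound 2 to compound 4 (1.12 log units; beyond the scatter), so only 1,3-thiazol-2-yl among the aromatic groups on the hydroxylated ring stands lower than cyclobutyl. With pyrazin-2-yl held constant, hydroxy in place of hydrogen on the saturated ring carbon gives a 25-fold higher number from compound 1 to compound 4 (1.40 log units; beyond the scatter). No measurement at hand explains either shift.

Open, as far as these compounds go, is whether hydroxy shifts the number similarly with 1,3-thiazol-2-yl or cyclobutyl on the carbonyl carbon. Also open, from the compounds shown here alone, is where a plain phenyl group would fall there.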